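Shortening the Amide Side Chain of Compound 3

A few compounds are considered here, and "the series" means these few. Any claim that something is new, unique, unknown or untested is made for them only; others in the source may bear on it.

Compound 3 `CCN1CC(NC(=O)[C@@H]2CCCN(S(=O)(=O)c3ccc(S(=O)(=O)N(CC)CC)cc3)C2)C1` was examined in a functional assay on MIA PaCa-2 cells (Homo sapiens) for inhibition, read by MTT assay, with a stated time of 3 days; a lower number here means a stronger inhibitor, a higher number a weaker inhibitor. In this assay compound 3 gives > 10000 nM, which is a limit of the assay and not a number. Compound 1 `CCN(CC)S(=O)(=O)c1ccc(S(=O)(=O)N2CCC[C@@H](C(=O)NC3CN(C(=O)C4CC4)C3)C2)cc1` gives > 10000 nM in this assay, again a limit. Compound 2 `CCN(CC)C(=O)[C@@H]1CCCN(S(=O)(=O)c2ccc(S(=O)(=O)N(CC)CC)cc2)C1` gives > 10000 nM in this assay, also a limit. The steps a step that the two limits leave unreadable from compound 1 to compound 2, a step that the two limits leave unreadable from compound 1 to compound 3 and a step that the two limits leave unreadable from compound 2 to compound 3 cannot be sized, because of the limit of > 10000 nM in this assay, at which 3 of the 3 values shown sit.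

Compound 4 `CCN(CC)S(=O)(=O)c1ccc(S(=O)(=O)N2CCC[C@@H](C(=O)NC)C2)cc1` differs from compound 3 by methyl in place of 1-ethylazetidin-3-yl on an amide-type nitrogen. For the measured compounds named here, no measured step bears on this change, and the three measured steps carry no readable size. Compound 4 is therefore expected to stay at the limit, the step from compound 3 being estimated as a step that the limit leaves unreadable from compound 3 to compound 4. Compound 4 is estimated at 20000 nM in this assay, between 5000 nM and 100000 nM.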

Compound 4, half-maximal inhibitory concentration: > 10000 nM
Compound 4 ended at the assay's limit (the forecaster's own chance of this, stated with the estimate: 85%); the middle value does not contradict the limit.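

For the compounds shown here, no step from compound 1, compound 2 or compound 3 to compound 4 can be read in this assay, because all four compounds sit at one limit: (the limit of > 10000 nM in this assay, at which 4 of the 4 values shown sit). The compounds shown leave open whether any amide side chain on this core gives a measurable value.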